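The compounds below may be only part of what the source reports. "The series", "measured", "known", "first", "only" and "open" are said of these compounds alone.

Measured in an ADME assay on Vero cells (Chlorocebus sabaeus) for cytotoxicity, read by MTT assay; on this read-out lower numbers stand for stronger inhibition and higher numbers for weaker inhibition:
- Compound 1 `C=CCOc1cc(OC)c(C(=O)/C=C/c2ccc(F)cc2)c(OCC=C)c1`: 13600 nM
- Compound 2 `C=CCOc1cc(OC)c(C(=O)/C=C/c2ccc(OC)cc2)c(OCC=C)c1`: 99900 nM

Among the compounds with values here, of these two compounds, compound 2 stands highest at 99900 nM in this assay, and its only neighbour on the scale is compound 1 at 13600 nM, a gap beyond the scatter.

Compound 3 `C=CCOc1cc(OC)c(C(=O)/C=C/c2ccco2)c(OCC=C)c1` has not yet been measured. It replaces the aromatic group of compound 2 (furan-2-yl in place of 4-methoxyphenyl on a double-bonded chain carbon bound to a double-bonded chain carbon), with furan-2-yl in place of 4-methoxyphenyl on a double-bonded chain carbon bound to a double-bonded chain carbon.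

Within the data shown here, one measured step bears on this, and only indirectly. It exchanges a group on the same aromatic ring and does not replace the ring itself (a 7.3-fold higher number from compound 1 to compound 2 (0.87 log units; beyond the scatter)). That modest step shows that the number responds to change in this part of the molecule, and that the methoxy compound lies at the high end. Compound 3 also loses the methoxy group, so a lower number is expected, though the data hold no measured exchange of the ring.

The expected change, somewhat smaller than the measured step, is a 3.3-fold lower number from compound 2 to compound 3 (0.52 log units; beyond the scatter) in this assay.

For compound 3 the estimate is 30000 nM, with an expected range from 8000 nM to 100000 nM.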

Compound 3, half-maximal inhibitory concentration: 191000 nM
Beside the measured number, compound 3's estimate is 6.4-fold (0.80 log units) below it; measured number above the stated range.
By their numbers in this assay, from the lowest: compound 1; then compounds 2 and 3 (each within the scatter of the next).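

In this assay, the exchange of furan-2-yl for 4-methoxyphenyl on a double-bonded chain carbon bound to a double-bonded chain carbon gives a 1.9-fold higher number from compound 2 to compound 3 (0.28 log units; within the scatter), so replacing the whole aromatic ring, a five-membered ring in place of a six-membered one, leaves compound 3 level with compound 2. The same ring exchange made against 4-fluorophenyl gives a 14-fold higher number from compound 1 to compound 3 (1.15 log units; beyond the scatter), a large step, so among these three compounds only the 4-fluorophenyl group of compound 1 stands apart, while the 4-methoxyphenyl and furan-2-yl groups sit together at the high end of the scale. Nothing measured here accounts for why compound 1 separates from the other two.

The compounds shown leave open whether the low number of compound 1 belongs to fluoro in particular, since no chloro or trifluoromethyl group on the same phenyl ring, and no unsubstituted phenyl, appears among them. Going by these compounds, it also remains open where a thiophene or pyridine ring at this place, or a phenyl ring carrying an amine or a carboxylic acid, would fall on this scale.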